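Cytotoxicity notes: from compound 3 to compound 4

A few compounds are considered here, and "the series" means these few. Any claim that something is new, unique, unknown or untested is made for them only; others in the source may bear on it.

The shared core is seen in compound 1 `CC1=C(C(=O)Nc2ccccc2Cl)C(c2ccccc2Cl)NC(=O)N1`, compound 2 `CC1=C(C(=O)Nc2ccccc2Cl)C(c2ccccc2Br)NC(=O)N1` and compound 3 `CC1=C(C(=O)Nc2ccccc2Cl)C(c2ccc(C)cc2)NC(=O)N1`. In an ADME assay on Vero cells (Chlorocebus sabaeus) for cytotoxicity, read by XTT assay, with a stated time of 72 h (on this read-out higher numbers stand for lower toxicity in this test and lower numbers for higher toxicity in this test), compound 1 is recorded as "non-toxic" (no number reported), without a number. In this assay compound 2 reaches only a limit of the test, > 100000 nM. Compound 3 likewise gives only a limit in this assay, > 100000 nM. For the measured compounds named here, the one measured step, a step that the two limits leave unreadable from compound 2 to compound 3, therefore cannot be sized, and compound 3 stands at the same boundary as the other numeric entry, as summed up by the limit of > 100000 nM in this assay, at which 2 of the 3 values shown sit. Compound 4 `CC1=C(C(=O)Nc2ccccc2Cl)C(c2cccc([N+](=O)[O-])c2)NC(=O)N1` is not yet measured in this assay. Its difference from compound 3 is 3-nitrophenyl in place of 4-methylphenyl on a saturated ring carbon. No measured step bears directly on this change; all that is shown is that two aryl variants on that saturated ring carbon sit at the limit and a third is called non-toxic. Compound 4 is therefore expected to show no step beyond the scatter, a number no higher from compound 3 to compound 4 (the limit leaves the size open), and its estimated value in this assay is 100000 nM, with a range from 40000 nM to 300000 nM, most probably again reported only as a limit.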

Compound 4, half-maximal cytotoxic concentration: "non-toxic" (no number reported)
Compound 4 has no reported number here, and the estimate cannot be compared.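

In this assay, for the compounds shown here, compound 4 is recorded as "non-toxic" (no number reported), so no step from compound 3 to compound 4 can be read. The compounds shown leave open what actual cytotoxic concentration any of these aryl variants has, since the numeric record stops at a limit: the limit of > 100000 nM in this assay, at which 2 of the 4 values shown sit.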